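Taking the chloro group off compound 1

This account rests on a few compounds, and the source may have more. Where it says the series, first, only, none or still open, it means among the compounds named here.

Compound 1 `COc1ccc(C2=C(c3cc(OC)c(OC)c(OC)c3)C(=O)C(OC(C)=O)C2)cc1Cl`: 24 ug/mL
Compound 2 `COC(=O)c1cc(C2=C(c3cc(OC)c(OC)c(OC)c3)C(=O)CC2O[SiH2]C(C)(C)C)ccc1OC`: > 100 ug/mL
Compound 3 `COCOc1cc(C2=C(c3cc(OC)c(OC)c(OC)c3)C(=O)CC2O[SiH2]C(C)(C)C)ccc1OC`: 50 ug/mL

In an ADME assay on MIA PaCa-2 cells (Homo sapiens) for cytotoxicity, read by MTT assay, with a stated time of 72 h (a lower number here means a stronger inhibitor, a higher number a weaker inhibitor), compound 1 gives 24 ug/mL, the lower of the two numbers measured. Compound 3 gives 50 ug/mL. For compound 2 the assay reports a limit rather than a number, > 100 ug/mL, which is the limit of > 100 ug/mL in this assay, at which 1 of the 3 values shown sits. Within the data shown here, the only measured step, an at least 2.0-fold lower number from compound 2 to compound 3 (0.30 log units; that floor lies within the scatter), concerns a change on the other aryl ring and does not touch the chloro group. Compound 4 `COc1ccc(C2=C(c3cc(OC)c(OC)c(OC)c3)C(=O)C(OC(C)=O)C2)cc1` differs from compound 1 by hydrogen in place of chloro on an aromatic carbon. Among the measured compounds shown here, no measured step bears on this change, so the expected step of a 1.5-fold higher number from compound 1 to compound 4 (0.16 log units; within the scatter) is set near the scatter, leaning toward a somewhat higher number. Compound 4 is therefore estimated at 35 ug/mL, between 15 ug/mL and 90 ug/mL.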

Compound 4, half-maximal inhibitory concentration: < 1 ug/mL
Compound 4 gave a limit, no number; the forecaster's own chance of this, stated with the estimate: 10%; at least 35-fold (1.54 log units) between middle value and limit.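

In this assay, among these compounds, hydrogen in place of chloro on this aromatic carbon, ortho to a methoxy group, gives an at least 24-fold lower number from compound 1 to compound 4 (1.38 log units; beyond the scatter), the first measured step at this position, and it is large and beyond the scatter. The earlier compounds shown here showed only a change on the other aryl ring, so they gave no sign of how much this position could matter. The value for compound 4 is a limit and not a number: the limit of < 1 ug/mL in this assay, at which 1 of the 4 values shown sits.

On these data alone, how far the number for compound 4 lies past that limit remains open. So does how a fluoro group, a methyl group or an amine on this same carbon would read.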